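Swapping chloro for methoxy on the phenyl ring of compound 2

The source may hold more compounds than are shown below. What is called first, only, known or untested is meant among the compounds shown, and "the series" means these compounds.

Of the compounds shown here, two have been measured in an assay on isolated protein for inhibition of Aromatase (Homo sapiens), read by ELISA, using NADPH, with a stated time of 24 h; a lower number here means a stronger inhibitor, a higher number a weaker inhibitor. Compound 1 `Fc1ccc2c(Cn3ccnc3)c(-c3ccc(Cl)cc3)[nH]c2c1` gives 82.9 nM and compound 2 `Clc1ccc(-c2[nH]c3cc(Cl)ccc3c2Cn2ccnc2)cc1` gives 261 nM. Within the data shown here, the only measured step, a 3.1-fold higher number from compound 1 to compound 2 (0.50 log units; beyond the scatter), comes from a chloro in place of fluoro on an aromatic carbon. Among the measured compounds shown here, compound 2 therefore stands as the higher of the two numbers, with compound 1 as its only neighbour.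

Compound 3 `COc1ccc(-c2[nH]c3cc(Cl)ccc3c2Cn2ccnc2)cc1` is not yet measured. It differs from compound 2 by methoxy in place of chloro on an aromatic carbon of a six-membered aromatic ring of carbon only. For the measured compounds named here, no measured step covers this exchange: the one known step concerns a halogen swap at a different place in the shared core, so it offers no direct guide. With nothing to point either way, the expected result in this assay is a change that stays near the scatter, in no firm direction. The estimate for compound 3 is 350 nM, within a range from 120 nM to 1000 nM, meaning an expected step of a 1.3-fold higher number from compound 2 to compound 3 (0.13 log units; within the scatter).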

Compound 3, half-maximal inhibitory concentration: 277 nM
Compound 3: the middle estimate sits 1.3-fold (0.10 log units) above what was measured; the measured number falls inside the stated range.
By their numbers in this assay, from the lowest: compound 1; then compounds 2 and 3 (each within the scatter of the next).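

In this assay, replacing 4-chlorophenyl with 4-methoxyphenyl gives a 1.1-fold higher number from compound 2 to compound 3 (0.03 log units; within the scatter) and so leaves the reading within the usual scatter. Among these compounds, this is the first view of the place on the phenyl ring para to a large group, whereas the earlier step, a 3.1-fold higher number from compound 1 to compound 2 (0.50 log units; beyond the scatter), concerned a halogen at a different place on the shared core and lay beyond the scatter. Here, a chloro and a methoxy, which differ in their heavy atoms and in that methoxy counts as a hydrogen-bond acceptor while chloro does not, cannot be told apart in this assay, although no measurement at hand explains why.

This one pair cannot show whether the same place would accept very different groups, such as an amine, a carboxylic acid or a longer chain like butoxy, or whether the readings would then move well beyond the scatter. It also leaves open whether methoxy and chloro would still read alike on the fluoro core of compound 1.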